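This account rests on a few compounds, and the source may have more. Where it says the series, first, only, none or still open, it means among the compounds named here.

Series notes, shared core, aryl group varied on the amide-type nitrogen. Compound 1 `COc1ccc2nc(C)cc(OCC(=O)Nc3ccc(Br)c(C)c3)c2c1` gives 15900 nM in a toxicity assay on HepG2 cells (Homo sapiens) for inhibition, read by CellTiter-Glo, with a stated time of 48 h; on this read-out lower numbers stand for stronger inhibition and higher numbers for weaker inhibition. Compound 3 `COc1ccc2nc(C)cc(OCC(=O)Nc3c(C)cncc3C)c2c1` gives 12600 nM in this assay, within the scatter of compound 1, as the step of a 1.3-fold lower number from compound 1 to compound 3 (0.10 log units; within the scatter) shows. Compound 2 `COc1ccc2nc(C)cc(OCC(=O)Nc3cccnc3)c2c1` reaches only the assay's limit in this assay, > 100000 nM (the limit of > 100000 nM in this assay, at which 1 of the 3 values shown sits). The steps of an at least 6.2-fold higher number from compound 1 to compound 2 (0.79 log units; beyond the scatter) and an at least 7.9-fold lower number from compound 2 to compound 3 (0.89 log units; beyond the scatter) are both beyond the scatter, so pyridin-3-yl stands apart from the two other groups on this nitrogen.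

Compound 4 `COc1ccc2nc(C)cc(OCC(=O)Nc3cc(C)nc(C)n3)c2c1` is not yet measured; the change is 2,6-dimethylpyrimidin-4-yl in place of 3,5-dimethylpyridin-4-yl on an amide-type nitrogen. Going by the values given here, two measured steps bear on it, both concerning a six-membered aromatic ring with a hetero atom on this nitrogen: pyridin-3-yl gave a limit, while 3,5-dimethylpyridin-4-yl stayed with the 4-bromo-3-methylphenyl compound 1. Compound 4 keeps both methyl groups but carries a second ring nitrogen, so a modest step toward weaker inhibition is expected, a 2.0-fold higher number from compound 3 to compound 4 (0.30 log units; within the scatter), with some chance of a limit. For compound 4 the estimate is 25000 nM, between 8000 nM and 100000 nM.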

Compound 4, half-maximal inhibitory concentration: > 100000 nM
Compound 4: a limit, no number; the forecaster's own chance of this, stated with the estimate: 30%; middle value at least 4.0-fold (0.60 log units) from the limit.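

In this assay compound 4 gives a limit and no number, the second such result in the series: the limit of > 100000 nM in this assay, at which 2 of the 4 values shown sit. Keeping two methyl groups on the ring is therefore not enough to hold the result seen with 3,5-dimethylpyridin-4-yl: 2,6-dimethylpyrimidin-4-yl brings an at least 7.9-fold higher number from compound 3 to compound 4 (0.89 log units; beyond the scatter), and against 4-bromo-3-methylphenyl it brings an at least 6.2-fold higher number from compound 1 to compound 4 (0.79 log units; beyond the scatter). The step between compound 2 and compound 4 cannot be read, as both values are limits.

The compounds shown leave open whether the second ring nitrogen or the changed arrangement of the methyl groups separates compound 4 from compound 3, as both changes come together in this one step. Also open, from the compounds shown here alone, is how a 2,6-dimethylpyridin-4-yl or a 3,5-dimethylphenyl group would read on this amide-type nitrogen.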